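The source may hold more compounds than are shown below. What is called first, only, known or untested is meant among the compounds shown, and "the series" means these compounds.

Compound 1 `Cc1cc(=O)n(-c2ccc(Br)cc2F)nc1C(=O)Nc1ccc(Oc2ncnc3[nH]ccc23)cc1` carries an amide joined to a bicyclic ether and, on the other side, a pyridazinone bearing a bromo-fluorophenyl group. In a functional assay on MCF7 cells (Homo sapiens) for cytotoxicity, read by MTT assay, with a stated time of 72 h (a lower number here means a stronger inhibitor, a higher number a weaker inhibitor), compound 1 gives 3210 nM, the lowest of the two numbers recorded. Going by the values given here, its only measured neighbour is compound 2 `Cc1cc(=O)n(-c2ccc(Br)cc2F)nc1C(=O)Nc1ccc(Oc2ncnc3[nH]ccc23)c(F)c1`, which differs by a fluoro in place of hydrogen on an aromatic carbon; in this assay compound 2 gives 26600 nM, and the step of an 8.3-fold higher number from compound 1 to compound 2 (0.92 log units; beyond the scatter) is a modest weakening.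

Compound 3 `Cc1cc(=O)n(-c2ccc(Br)cc2F)nc1C(=O)Nc1ccc(Oc2ncnc3c2ccn3C)cc1` has not yet been measured. It differs from compound 1 by methyl in place of hydrogen on an aromatic nitrogen. Among the compounds with values here, no measured pair shows this kind of change; the only step available, from compound 1 to compound 2, concerns a different position and a different group, so it offers no direct guide. The step is therefore estimated as a 1.6-fold higher number from compound 1 to compound 3 (0.19 log units; within the scatter), with wide uncertainty. Compound 3 is expected to give about 5000 nM in this assay, somewhere between 1500 nM and 20000 nM.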

Compound 3, half-maximal inhibitory concentration: 27700 nM
The estimate for compound 3 lay 5.5-fold (0.74 log units) below the measured number; the whole stated range lies below it.
By their numbers in this assay, from the lowest: compound 1; then compounds 2 and 3 (each within the scatter of the next).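

In this assay, replacing the hydrogen on this aromatic nitrogen with a methyl gives an 8.6-fold higher number from compound 1 to compound 3 (0.94 log units; beyond the scatter) and so weakens the compound beyond the scatter. Going by these compounds alone, this is the first view of this part of the molecule, since the earlier step concerned a different position. In this one pair, a change of a single carbon atom at this nitrogen is not tolerated without loss, and nothing measured here explains that loss.

From the compounds shown here alone, it remains open whether a longer chain such as ethyl, or a chain ending in an amine or a carboxylic acid, would behave like methyl on this nitrogen. Going by these compounds, it is also open whether the same methyl would cause a similar loss on compound 2, which already carries the added fluoro.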